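A few compounds are considered here, and "the series" means these few. Any claim that something is new, unique, unknown or untested is made for them only; others in the source may bear on it.

Measured compounds:
compound 1 `Cc1ccccc1Nc1nc(Nc2cccnc2)ncc1Cl` — 41200 nM
compound 2 `Cc1ccccc1Nc1nc(NC2CC2)ncc1Cl` — a limit of the assay, > 100000 nM

In a functional assay on MDA-MB-231 cells (Homo sapiens) for inhibition, read by CCK-8 assay, with a stated time of 48 h (on this read-out higher numbers stand for weaker inhibition of growth and lower numbers for stronger inhibition of growth), compound 1 gives 41200 nM, the only finite number shown. For compound 2 the read-out stops at the limit of > 100000 nM in this assay, at which 1 of the 2 values shown sits. Among the compounds with values here, the sole measured step, an at least 2.4-fold higher number from compound 1 to compound 2 (0.38 log units; beyond the scatter), exchanges the same pyridin-3-yl that compound 3 `Cc1ccccc1Nc1nc(NCc2ccccc2)ncc1Cl` also lacks: benzyl in place of pyridin-3-yl on a nitrogen on an aromatic ring. Benzyl keeps one six-membered aromatic ring, unlike cyclopropyl, and the cyclopropyl step is taken only as a loose guide. A modest weakening beyond the scatter is expected, a 2.1-fold higher number from compound 1 to compound 3 (0.31 log units; beyond the scatter). Compound 3 is estimated at 85000 nM, range 30000 nM to 250000 nM, with a real chance that only a limit is returned.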

Compound 3, concentration for 50% growth inhibition: > 100000 nM
Compound 3: no number, only a limit (the forecaster's own chance of this, stated with the estimate: 40%); middle value at least 1.1-fold (0.07 log units) from the limit.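

Keeping a six-membered aromatic ring at this place does not preserve the read-out of compound 1: benzyl gives an at least 2.4-fold higher number from compound 1 to compound 3 (0.38 log units; beyond the scatter). Among the compounds shown, only pyridin-3-yl on this nitrogen gives a finite number, while cyclopropyl and benzyl both end at the same limit in this assay: the limit of > 100000 nM in this assay, at which 2 of the 3 values shown sit. The step between compound 2 and compound 3 cannot be read, as both values are limits.

From the compounds shown here alone, how far compound 2 and compound 3 lie past that limit stays open. Also open, going by these compounds, is whether phenyl or pyridin-4-yl directly on this nitrogen would give a finite number.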